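Fluoro in place of hydrogen: compound 2 to compound 3

The compounds below may be only part of what the source reports. "The series", "measured", "known", "first", "only" and "open" are said of these compounds alone.

Of the compounds shown here, two have numbers so far. In a functional assay on L1210 cells (Mus musculus) for antiproliferative activity, with a stated time of 48 h (on this read-out higher numbers stand for weaker inhibition and lower numbers for stronger inhibition), compound 2 (`Nc1ccc(/C=C/C(=O)c2ccccc2)cc1`) gives 88000 nM, the higher of the two numbers and so the weaker inhibition. Compound 1 (`C=C(Br)C(=O)Nc1ccc(/C=C/C(=O)c2ccc(F)cc2)cc1`) gives 1600 nM, a lower number by a gap well beyond the scatter. Among the compounds with values here, these two compounds differ in more than one place, so their gap cannot be assigned to any single change, and no measured pair yet differs in one place only.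

The next compound to be read is compound 3 (`Nc1ccc(/C=C/C(=O)c2ccc(F)cc2)cc1`), which carries fluoro in place of hydrogen on an aromatic carbon, para to a large group: fluoro in place of hydrogen on an aromatic carbon. Within the data shown here, the series offers no measured example of this change alone, so the expectation stays cautious. A small move toward a lower number is expected, probably not beyond the scatter, and the estimated step is a 1.5-fold lower number from compound 2 to compound 3 (0.17 log units; within the scatter). In this assay, the estimate for compound 3 is 60000 nM, with an expected range from 25000 nM to 130000 nM.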

Compound 3, half-maximal inhibitory concentration: 123000 nM
Compound 3: the middle estimate sits 2.1-fold (0.31 log units) below what was measured; low and high end bracket the measured number.
By their numbers in this assay, from the lowest: compound 1; then compounds 2 and 3 (each within the scatter of the next).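

In this assay, fluoro in place of hydrogen on an aromatic carbon, para to a large group, gives a 1.4-fold higher number from compound 2 to compound 3 (0.15 log units; within the scatter), so with the amino group left open on the nitrogen this change does not separate the two compounds. Within the data shown here, the first single-place change beyond the scatter lies on the nitrogen: with fluoro present in both compounds, hydrogen in place of (1-bromoethenyl)carbonyl gives a 77-fold higher number from compound 1 to compound 3 (1.89 log units; beyond the scatter), which ties a large share of the activity in this pair to that group. No measurement on hand bears on the cause of either step.

The compounds shown leave open whether the step on the nitrogen rests on the bromine or on the carbonyl, a question that an acetyl or an acryloyl group on the same nitrogen would address. Also open, as far as these compounds go, are whether the fluoro step stays within the scatter when (1-bromoethenyl)carbonyl sits on the nitrogen, and how chloro or methoxy would read on the same aromatic carbon.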